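This account rests on a few compounds, and the source may have more. Where it says the series, first, only, none or still open, it means among the compounds named here.

Measured so far: compound 1 `Cc1cn([C@@H]2O[C@H](CO[Si](C)(C)C(C)(C)C)[C@@]3(OS(=O)(=O)C=C3NCC(=O)C(=O)N3CCC3)[C@H]2O[Si](C)(C)C(C)(C)C)c(=O)n(C)c1=O`, in a functional assay on HEL cells (Homo sapiens) for cytotoxicity, read by microscopy (on this read-out lower numbers stand for higher toxicity in this test and higher numbers for lower toxicity in this test), compound 1 gives 65000 nM; compound 3 `Cc1cn([C@@H]2O[C@H](CO[Si](C)(C)C(C)(C)C)[C@@]3(OS(=O)(=O)C=C3NCCC(=O)O)[C@H]2O[Si](C)(C)C(C)(C)C)c(=O)n(C)c1=O` gives 80000 nM. Compound 2 `COC(=O)C(=O)CNC1=CS(=O)(=O)O[C@@]12[C@@H](CO[Si](C)(C)C(C)(C)C)O[C@@H](n1cc(C)c(=O)n(C)c1=O)[C@@H]2O[Si](C)(C)C(C)(C)C` gives only a limit of the test, > 400000 nM.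

Compound 3 has the higher of the two numbers, and its nearest neighbour is compound 1, with a 1.2-fold higher number from compound 1 to compound 3 (0.09 log units; within the scatter). Compound 4 `Cc1cn([C@@H]2O[C@H](CO[Si](C)(C)C(C)(C)C)[C@@]3(OS(=O)(=O)C=C3NC(=O)NC(=O)c3ccccc3)[C@H]2O[Si](C)(C)C(C)(C)C)c(=O)n(C)c1=O` differs from compound 3 by benzoylcarbamoyl in place of 2-carboxyethyl on an amine nitrogen. Two earlier steps change the chain on that same amine nitrogen: a 1.2-fold higher number from compound 1 to compound 3 (0.09 log units; within the scatter) and an at least 5.0-fold lower number from compound 2 to compound 3 (0.69 log units; beyond the scatter), the second resting on the limit (the limit of > 400000 nM in this assay, at which 1 of the 3 values shown sits). One lies within the scatter and one beyond, so a step of modest size in either direction, or none, is expected here. Compound 4 is therefore estimated at 90000 nM, between 30000 nM and 300000 nM. The expected step is a 1.1-fold higher number from compound 3 to compound 4 (0.05 log units; within the scatter).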

Compound 4, minimum cytotoxic concentration: >= 80000 nM
Compound 4 gave a limit, no number; the forecaster's own chance of this, stated with the estimate: 15%; the middle value does not contradict the limit.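

On this amine nitrogen, the larger benzoylcarbamoyl group, with its six-membered aromatic ring, brings no gain in toxicity in this assay: the result is a number no lower from compound 3 to compound 4 (the limit leaves the size open). A second comparison gives an at least 1.2-fold higher number from compound 1 to compound 4 (0.09 log units; that floor lies within the scatter). The step between compound 2 and compound 4 cannot be read, and compound 4 itself gives only a limit: the limit of >= 80000 nM in this assay, at which 1 of the 4 values shown sits.

From the compounds shown here alone, how far the true value of compound 4 lies from that limit stays open, so any real drop in toxicity remains unsettled. Also open, going by these compounds, is how an acetyl group or a chain ending in an amine would read on this nitrogen.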